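A few compounds are considered here, and "the series" means these few. Any claim that something is new, unique, unknown or untested is made for them only; others in the source may bear on it.

In a functional assay on HOP-62 cells (Homo sapiens) for inhibition, read by sulforhodamine B assay, with a stated time of 48 h, tested at 10 uM (on this read-out higher numbers stand for a weaker effect at the one concentration tested and lower numbers for a stronger effect), the measured compounds gave:
Compound 1 `COc1cc(Cl)cc(-c2nn(-c3cccc(NC(=O)Nc4ccc(Cl)c(C(F)(F)F)c4)c3)cc2-c2ccncc2)c1`: 13.5%
Compound 2 `COc1cc(Cl)cc(-c2nn(-c3cccc(NC(=O)c4cccc(C(F)(F)F)c4)c3)cc2-c2ccncc2)c1`: 71.6%
Compound 3 `O=C(Nc1cccc(-n2cc(-c3ccncc3)c(-c3cc(O)cc(Cl)c3)n2)c1)c1cc(C(F)(F)F)cc(C(F)(F)F)c1`: 58.3%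

Compound 3 stands second highest of these three numbers: compound 2 is its nearest neighbour and lies higher than it beyond the scatter, while compound 1 lies far lower. Compound 4 `COc1cc(Cl)cc(-c2nn(-c3cccc(NC(=O)c4cc(C(F)(F)F)cc(C(F)(F)F)c4)c3)cc2-c2ccncc2)c1` is compound 3 with methyl in place of hydrogen on an oxygen on an aromatic ring. Among the compounds with values here, no measured step touches this oxygen. Within the data shown here, the only measured step, a number 58.1 percentage points higher from compound 1 to compound 2 (beyond the scatter), alters the group on the carbonyl carbon instead, so it says nothing about a methyl entering here. Compounds 2 and 3 differ in two places at once, so their values only show that they sit a modest distance apart. Among the measured compounds shown here, with no direct precedent, the step of a number 1.7 percentage points higher from compound 3 to compound 4 (within the scatter) is expected to be small. Compound 4 is estimated at 60%, with a range from 35% to 85%.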

Compound 4, a percentage reported as activity, at one concentration (the size of the read-out at that concentration, not a potency): 103%
Compound 4: middle estimate off by 43 percentage points, on the low side, outside the stated range (above it).
By their numbers in this assay, from the lowest: compound 1; then compound 3; then compound 2; then compound 4.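

In this assay the change from hydroxy to methoxy on the aromatic ring is far from silent: it gives a number 44.7 percentage points higher from compound 3 to compound 4 (beyond the scatter) and so a much weaker effect from a single added methyl. With methoxy kept, adding trifluoromethyl on an aromatic carbon gives a number 31.4 percentage points higher from compound 2 to compound 4 (beyond the scatter) and weakens the effect as well. Nothing available explains either step.

Still open, going by these compounds, is how an amine or an ethoxy group in place of the hydroxy would read here. On these data alone, it is also open whether the methoxy step stays this large with another group on the carbonyl carbon.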